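The compounds below may be only part of what the source reports. "The series", "measured", "known", "first", "only" and "open" are said of these compounds alone.

Measured so far:
Compound 1 `FC(F)(F)c1cccc(-c2nc3cnc(Nc4ccccn4)cc3[nH]2)c1`; in a physicochemical assay for solubility, using the shake flask method, in phosphate buffer, measured as kinetic solubility, with a stated time of 20 h, at pH 6.5 (a lower number here means a less soluble compound, a higher number a more soluble compound), compound 1 gives < 5000 nM, which is a limit of the assay and not a number.
Compound 2 `NC(=O)c1ccc(Nc2cc3[nH]c(-c4cccc(C(F)(F)F)c4)nc3cn2)nc1`; in this assay compound 2 gives < 5000 nM, again a limit of the assay.

Compound 2 therefore stands only at a limit, with no number of its own. Among the compounds with values here, the single step between measured compounds, a step that the two limits leave unreadable from compound 1 to compound 2, cannot be read because of the limit of < 5000 nM in this assay, at which 2 of the 2 values shown sit.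

Compound 3 `FC(F)(F)c1cccc(-c2nc3cnc(Nc4ccc(-c5nnn[nH]5)cn4)cc3[nH]2)c1` differs from compound 2 in one place: 1H-tetrazol-5-yl in place of carbamoyl on an aromatic carbon. No measured step bears on this change, and the one step shown is unreadable, so neither direction nor size can be drawn from the data. Compound 3 is expected to sit near the same limit, with an estimated value of 3000 nM, ranging from 500 nM to 15000 nM. The expected step is a step that the limit leaves unreadable from compound 2 to compound 3, which is no more than a placeholder within the usual scatter.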

Compound 3, solubility: < 5000 nM
Compound 3 ended at the assay's limit (the forecaster's own chance of this, stated with the estimate: 65%); the middle value is on the limit's open side.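

No new step can be read from compound 3 to compound 2 or compound 1, because all three results are a limit of the assay and not a number: the limit of < 5000 nM in this assay, at which 3 of the 3 values shown sit.

Left open is how compound 1, compound 2 and compound 3 rank, and whether carbamoyl or 1H-tetrazol-5-yl makes any difference.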